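The compounds below may be only part of what the source reports. "The series", "measured", "known", "first", "only" and "open" are said of these compounds alone.

Measured so far:
compound 1 `O=C(CN(c1nc(Cl)nc2[nH]cnc12)C1CC1)N[C@@H](CO)C(=O)OCc1ccccc1`, 34.5%
compound 2 `CSCC[C@H](NC(=O)CN(c1nc(Cl)nc2[nH]cnc12)C1CC1)C(=O)OCc1ccccc1`, 44.6%

Among the compounds with values here, compound 2 stands highest of the two numbers known in a functional assay on the whole organism (Tail, strain ICR) with Mus musculus as the target, in the tail flick test, with a stated time of 90 min, at a dose of 25 umol/kg by the oral route (on this read-out lower numbers stand for a weaker effect and higher numbers for a stronger effect at the one dose given), and the only measured step, a number 10.1 percentage points higher from compound 1 to compound 2 (beyond the scatter), separates it from compound 1. Compound 3 `NC(=O)C[C@H](NC(=O)CN(c1nc(Cl)nc2[nH]cnc12)C1CC1)C(=O)OCc1ccccc1` is not yet measured; it differs from compound 2 by carbamoyl in place of (methylsulfanyl)methyl on a saturated chain carbon, two bonds along the chain from an amide-type nitrogen and a carbonyl carbon. Within the data shown here, the one step on record bears on this change only loosely: it exchanged hydroxy for (methylsulfanyl)methyl at the same place and raised the read-out modestly. Here the (methylsulfanyl)methyl group leaves again and a group with a hydrogen-bond donor, as hydroxy has, enters instead, so a move back toward the number of compound 1 is expected, though the two groups are not the same. The expected step is a number 9.6 percentage points lower from compound 2 to compound 3 (within the scatter), a modest drop. Compound 3 is thus estimated at 35%, within a range of 22% to 49%.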

Compound 3, a percentage reported as activity, at one dose (the size of the read-out at that dose, not a potency): 32.3%
The estimate for compound 3 lay 2.7 percentage points above the measured number, within the range that was stated.
By their numbers in this assay, from the lowest: compounds 3 and 1 (each within the scatter of the next); then compound 2.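

In this assay the exchange of (methylsulfanyl)methyl for carbamoyl on this saturated chain carbon gives a number 12.3 percentage points lower from compound 2 to compound 3 (beyond the scatter) and so shows that a second group, besides hydroxy, separates from (methylsulfanyl)methyl at this place. Carbamoyl in place of hydroxy gives a number 2.2 percentage points lower from compound 1 to compound 3 (within the scatter) and leaves these two groups indistinguishable on this read-out, so that among the three compounds only compound 2 stands apart. Nothing measured here offers an explanation for this separation.

Going by these compounds, it remains open whether the sulfur atom of the 2-(methylsulfanyl)ethyl chain matters or whether a plain butyl chain would read the same. On these data alone, it is also open whether a carboxylic acid or an amine at this place would fall with hydroxy and carbamoyl or with (methylsulfanyl)methyl.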